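The source may report more compounds than this note shows. Statements on the series, on what has been measured and on what is new or still open speak of the compounds shown alone.

In an ADME assay on MDBK cells (Bos taurus) for cytotoxicity, read by MTT assay, with a stated time of 96 h (a higher number here means that more compound is tolerated, a lower number that less compound is tolerated), compound 1 `COc1ccc(-c2nc3cc(C(F)(F)F)ccc3[nH]2)c(N)c1` gives 4000 nM, compound 2 `O=C(CN1CCCC1)Nc1ccc(-c2nc3cc(C(F)(F)F)ccc3[nH]2)cc1` gives 15000 nM, and compound 3 `CCN(CC)CC(=O)Nc1ccc(-c2nc3cc(C(F)(F)F)ccc3[nH]2)cc1` gives 13000 nM. Compound 3 thus stands second highest of the three, close to compound 2 and beyond the scatter from compound 1. Compound 4 `COc1ccc(-c2nc3cc(C(F)(F)F)ccc3[nH]2)cc1` differs from compound 3 by methoxy in place of (((diethylamino)methyl)carbonyl)amino on an aromatic carbon. Within the data shown here, only one measured step exists, a 1.2-fold lower number from compound 2 to compound 3 (0.06 log units; within the scatter), and it swaps one chain end for another, so it says little about removing the whole chain. Compound 1, which carries the same methoxy group, sits lower than compound 3, so a drop is expected in this assay, roughly a 2.2-fold lower number from compound 3 to compound 4 (0.34 log units; beyond the scatter). Compound 4 is therefore estimated at 6000 nM, between 2000 nM and 20000 nM.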

Compound 4, half-maximal cytotoxic concentration: > 100000 nM
Compound 4 was reported as a limit; the forecaster's own chance of this, stated with the estimate: 10%; at least 16-fold (1.22 log units) between middle value and limit.
By their numbers in this assay, from the lowest: compound 1; then compounds 3 and 2 (each within the scatter of the next). At a limit, above all of these: compound 4.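

In this assay compound 4 stands at a limit of the assay, not a number: the limit of > 100000 nM in this assay, at which 1 of the 4 values shown sits.
On this aromatic carbon, methoxy in place of (((diethylamino)methyl)carbonyl)amino gives an at least 7.6-fold higher number from compound 3 to compound 4 (0.88 log units; beyond the scatter), and methoxy in place of (((pyrrolidin-1-yl)methyl)carbonyl)amino gives an at least 6.6-fold higher number from compound 2 to compound 4 (0.82 log units; beyond the scatter), so removing either whole chain moves the number the same way, while swapping one chain end for the other stayed within the scatter. Hydrogen in place of amino on an aromatic carbon gives an at least 25-fold higher number from compound 1 to compound 4 (1.39 log units; beyond the scatter), so that single amino group also matters here.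

From the compounds shown here alone, how far compound 4 lies beyond its limit stays open. So does what an ethoxy group or a free amine would give in place of methoxy.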